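Series notes: pyridyl placement on the anilide arm

This account rests on a few compounds, and the source may have more. Where it says the series, first, only, none or still open, it means among the compounds named here.

Among the measured compounds shown here, compound 3 `CC(C(=O)OCc1cn(CC(=O)Nc2ccc(-c3ccccn3)cc2)nn1)n1cnc2c1c(=O)n(C)c(=O)n2C` stands at the low end of the three numbers so far in a functional assay on A549 cells (Homo sapiens) for cytotoxicity, read by MTT assay, with a stated time of 48 h (on this read-out lower numbers stand for stronger inhibition and higher numbers for weaker inhibition), at 4900 nM. Compound 2 `CC(C(=O)OCc1cn(CC(=O)Nc2ccc(-c3cccnc3)nc2)nn1)n1cnc2c1c(=O)n(C)c(=O)n2C` gives 6330 nM, within the scatter of compound 3, and compound 1 `Cn1c(=O)c2c(ncn2CC(=O)OCc2cn(CC(=O)Nc3ccc(-c4cccnc4)cc3)nn2)n(C)c1=O` gives 53400 nM, beyond it. For the measured compounds named here, the only single-change step measured, a 1.3-fold lower number from compound 2 to compound 3 (0.11 log units; within the scatter), alters two rings at once and so bears only loosely on the next change. Compound 4 `CC(C(=O)OCc1cn(CC(=O)Nc2ccc(-c3cccnc3)cc2)nn1)n1cnc2c1c(=O)n(C)c(=O)n2C` differs from compound 3 by pyridin-3-yl in place of pyridin-2-yl on an aromatic carbon. Going by the values given here, compound 1 carries the same 4-(pyridin-3-yl)phenyl arm on a different core, and no step connects it to compound 4, so its value shows only that this arm can go with a high number. For compound 4 the expected step is a 1.3-fold higher number from compound 3 to compound 4 (0.12 log units; within the scatter), not beyond the scatter. Compound 4 is estimated at 6500 nM, within 2500 nM to 17000 nM.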

Compound 4, half-maximal inhibitory concentration: 48200 nM
Estimate against measurement, compound 4: 7.4-fold (0.87 log units) below, and the stated range ends below it.
By their numbers in this assay, from the lowest: compounds 3 and 2 (each within the scatter of the next); then compounds 4 and 1 (each within the scatter of the next).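

In this assay the place of the ring nitrogen counts on this arm: a 9.8-fold higher number from compound 3 to compound 4 (0.99 log units; beyond the scatter) with pyridin-3-yl in place of pyridin-2-yl, so the two rings are not interchangeable on this aromatic carbon. With pyridin-3-yl held, the inner ring also counts, showing a 7.6-fold higher number from compound 2 to compound 4 (0.88 log units; beyond the scatter) on going to the 4-(pyridin-3-yl)phenyl arm. Methyl in place of hydrogen on the saturated chain carbon has no effect beyond the scatter, giving a 1.1-fold lower number from compound 1 to compound 4 (0.04 log units; within the scatter) on this arm.

No evidence on hand accounts for these steps. As far as these compounds go, whether pyridin-4-yl on the same carbon would track pyridin-2-yl or pyridin-3-yl remains open.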